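The source may report more compounds than this note shows. Statements on the series, on what has been measured and on what is new or still open speak of the compounds shown alone.

Values measured so far in an ADME assay on MT4 cells (Homo sapiens) for cytotoxicity, read by MTT assay, with a stated time of 5 days (on this read-out lower numbers stand for higher toxicity in this test and higher numbers for lower toxicity in this test), are these.
- compound 1 `Cc1cc(C)cc(S(=O)(=O)c2c(C(=O)N[C@@H]3CCN(S(C)(=O)=O)C3)[nH]c3ccc(Cl)cc23)c1` gives 24000 nM
- compound 2 `Cc1cc(C)cc(S(=O)(=O)c2c(C(=O)N[C@@H]3CCN(CC(N)=O)C3)[nH]c3ccc(Cl)cc23)c1` gives 31000 nM
- compound 3 `Cc1cc(C)cc(S(=O)(=O)c2c(C(=O)NC3CN(S(C)(=O)=O)C3)[nH]c3ccc(Cl)cc23)c1` gives > 252000 nM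

Compound 3 stands at the limit of > 252000 nM in this assay, at which 1 of the 3 values shown sits, so its entry is a limit and not a number.

It also stands clear of the other two compounds. The change to 1-(methylsulfonyl)azetidin-3-yl gave an at least 10-fold higher number from compound 1 to compound 3 (1.02 log units; beyond the scatter), and the comparison with the carbamoylmethyl compound gave an at least 8.1-fold higher number from compound 2 to compound 3 (0.91 log units; beyond the scatter).

Compound 4 `Cc1cc(C)cc(S(=O)(=O)c2c(C(=O)NC3CN(CC(N)=O)C3)[nH]c3ccc(Cl)cc23)c1` has not yet been measured. It keeps the 1-azetidin-3-yl framing of compound 3 but carries carbamoylmethyl in place of methylsulfonyl on an amine nitrogen in a ring.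

The closest guide is the same swap made on the pyrrolidine-bearing pair, which gave a 1.3-fold higher number from compound 1 to compound 2 (0.11 log units; within the scatter). That is a single example, and on a different ring. Resting on it, no step beyond the scatter is expected here, and the estimated change is an at least 1.2-fold lower number from compound 3 to compound 4 (0.10 log units; that floor lies within the scatter). For compound 4 the estimated value is 200000 nM, with an expected range from 60000 nM to 270000 nM.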

Compound 4, half-maximal cytotoxic concentration: 25500 nM
For compound 4 the middle estimate is 7.8-fold (0.89 log units) above the measured one; the whole stated range lies above it.
By their numbers in this assay, from the lowest: compounds 1, 4 and 2 (each within the scatter of the next). At a limit, above all of these: compound 3.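

Carbamoylmethyl in place of methylsulfonyl on the four-membered ring gave an at least 9.8-fold lower number from compound 3 to compound 4 (0.99 log units; beyond the scatter) in this assay, so this change does not carry over from one ring to the other: the same change on two cores in this assay, a 1.3-fold higher number (0.11 log units; within the scatter) from compound 1 to compound 2 and an at least 9.8-fold lower number (0.99 log units; beyond the scatter) from compound 3 to compound 4, at least 12-fold (1.10 log units) apart, beyond the scatter of two such steps

The four-membered ring alone does not set compound 3 apart: with carbamoylmethyl on that ring, the steps read a 1.2-fold lower number from compound 2 to compound 4 (0.08 log units; within the scatter) and a 1.1-fold higher number from compound 1 to compound 4 (0.03 log units; within the scatter). The entry for compound 3 is a limit and not a number: the limit of > 252000 nM in this assay, at which 1 of the 4 values shown sits.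

From the compounds shown here alone, the true value of compound 3 remains unknown, so the step to compound 4 has only a floor. Going by these compounds, it also remains open whether the high number is specific to methylsulfonyl on this nitrogen, or whether an acetyl group or a longer chain ending in an amine would behave the same way.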